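A few compounds are considered here, and "the series" means these few. Any claim that something is new, unique, unknown or untested is made for them only; others in the source may bear on it.

Measured so far:
Compound 1 `Nc1ccccc1-c1cnc(C(=O)CCCCCCc2ccccc2)o1`; in an assay (Rattus norvegicus) for inhibition of Fatty-acid amide hydrolase 1 (Homo sapiens) (a lower number here means a stronger inhibitor, a higher number a weaker inhibitor), compound 1 gives 750 nM.
Compound 2 `NC(=O)c1ccc(-c2cnc(C(=O)CCCCCCc3ccccc3)o2)cc1`; in this assay compound 2 gives 10 nM.
Compound 3 `Cc1ccc(-c2cnc(C(=O)CCCCCCc3ccccc3)o2)nc1`; in this assay compound 3 gives 2.8 nM.

Compound 3 stands lowest of the three numbers in this assay: its nearest neighbour is compound 2, with a 3.6-fold lower number from compound 2 to compound 3 (0.55 log units; beyond the scatter), and the furthest is compound 1, with a 270-fold lower number from compound 1 to compound 3 (2.43 log units; beyond the scatter). Both steps lie beyond the scatter, so compound 3 is the strongest inhibitor of the three.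

Compound 4 `CN1CCN(C(=O)c2cnc(C(=O)CCCCCCc3ccccc3)o2)CC1` differs from compound 3 at one place: (4-methylpiperazin-1-yl)carbonyl in place of 5-methylpyridin-2-yl on an aromatic carbon.

All three measured steps bear on this change, since each exchanges the group on the same aromatic carbon of the shared core. They were large: a 75-fold lower number from compound 1 to compound 2 (1.88 log units; beyond the scatter), a 270-fold lower number from compound 1 to compound 3 (2.43 log units; beyond the scatter) and, more modestly, a 3.6-fold lower number from compound 2 to compound 3 (0.55 log units; beyond the scatter). What sits at this place therefore moves the number in this assay strongly. Among the compounds with values here, none of the measured steps, however, swaps a six-membered aromatic ring for a six-membered non-aromatic ring joined through a carbonyl, so the size of the coming step is uncertain. With compound 3 already at the lowest number, the expected direction is upward, and the step from compound 3 to compound 4 is estimated as an 18-fold higher number from compound 3 to compound 4 (1.25 log units; beyond the scatter). Compound 4 is expected to give about 50 nM, in the range 8 nM to 300 nM.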

Compound 4, inhibition constant: 80 nM
Beside the measured number, compound 4's estimate is 1.6-fold (0.20 log units) below it; measured number inside the range.
By their numbers in this assay, from the lowest: compound 3; then compound 2; then compound 4; then compound 1.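

Within the data shown here, compound 4 is the first compound here whose group on this aromatic carbon is a non-aromatic ring joined through a carbonyl. In this assay this group falls inside the span set by the aromatic groups, with a 29-fold higher number from compound 3 to compound 4 (1.46 log units; beyond the scatter) and an 8.0-fold higher number from compound 2 to compound 4 (0.90 log units; beyond the scatter) but also a 9.4-fold lower number from compound 1 to compound 4 (0.97 log units; beyond the scatter). An aromatic ring directly on this carbon is therefore not enough on its own for a low number, as compound 1 shows, and it is not required for a number well under that of compound 1, as compound 4 shows, although compound 2 and compound 3 still stand lower; no measurement offered here accounts for this order.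

Compound 4 changes the ring and adds the carbonyl link in a single step, so the compounds shown cannot separate what each of the two contributes. As far as these compounds go, it also remains open whether a piperidin-1-ylcarbonyl group, with one ring nitrogen and no methyl, or a carboxylic acid on this carbon would give a number closer to that of compound 3 or to that of compound 1.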